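The compounds below may be only part of what the source reports. "The series", "measured", "known", "first", "only" and "open" are said of these compounds alone.

Measured so far in an assay on isolated protein for inhibition of Alpha-2C adrenergic receptor (Homo sapiens); on this read-out lower numbers stand for stronger inhibition and higher numbers for weaker inhibition:
- compound 1 `CN(CCCCN(C[C@H]1Cc2ncccc2CN1)[C@H]1CCCc2cccnc21)C1CCC(F)(F)CC1`: > 30000 nM
- compound 2 `CN(CCCCN(C[C@H]1Cc2ncccc2CN1)[C@H]1CCCc2cccnc21)C1CCOCC1`: for compound 2 the value is 8400 nM

The value of compound 1 is only a limit of this assay, the one at the limit of > 30000 nM in this assay, at which 1 of the 2 values shown sits. Compound 3 `c1cnc2c(c1)CN[C@@H](CN(CCCC1CCNCC1)[C@H]1CCCc3cccnc31)C2` differs from compound 1 by a group of 6 heavy atoms (5 carbon, 1 nitrogen; one six-membered non-aromatic ring with 1 hetero atom) in place of a group of 11 heavy atoms (8 carbon, 1 nitrogen, 2 fluorine; one six-membered non-aromatic ring of carbon only), on a saturated chain carbon, three bonds along the chain from an amine nitrogen. Among the measured compounds shown here, the one measured step that bears on it is an at least 3.5-fold lower number from compound 1 to compound 2 (0.55 log units; beyond the scatter), where a ring with one hetero atom also took the place of 4,4-difluorocyclohexyl. A step in the same direction, of similar size, is therefore expected, an at least 3.0-fold lower number from compound 1 to compound 3 (0.47 log units; beyond the scatter). For compound 3 a value near 10000 nM is estimated, between 3000 nM and 30000 nM.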

Compound 3, half-maximal inhibitory concentration: 2200 nM
Beside the measured number, compound 3's estimate is 4.5-fold (0.66 log units) above it; measured number outside the range, below it.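

In this assay, piperidin-4-yl on this saturated chain carbon gives an at least 13-fold lower number from compound 1 to compound 3 (1.13 log units; beyond the scatter) and a 3.8-fold lower number from compound 2 to compound 3 (0.58 log units; beyond the scatter). Compound 3 therefore has the lowest number of the three, so the amine-linked rings of compound 1 and compound 2 are not needed for a lower number at this place. Compound 1 remains a limit of the assay, so its step is only a bound: the limit of > 30000 nM in this assay, at which 1 of the 3 values shown sits.

The step from compound 2 changes the ring and removes the methylamino link together, leaving their shares unseparated. Cyclohexyl or 1-methylpiperidin-4-yl at this place would bear on that question.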